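The compounds below may be only part of what the source reports. "The series", "measured", "known", "first", "only" and "open" are said of these compounds alone.

Compound 1 `OCc1cc2ccccc2nc1-c1ccccc1O` is the unsubstituted parent of the set; in a functional assay on COLO 205 cells (Homo sapiens) for cytotoxicity, read by MTT assay, with a stated time of 24 h (a higher number here means a weaker inhibitor, a lower number a stronger inhibitor), compound 1 gives 40000 nM. Compound 2 `Cc1ccc2nc(-c3ccccc3O)c(CO)cc2c1` carries a methyl on the shared core. In this assay compound 2 reaches only a limit, > 100000 nM, and no number is reported. Compound 3 `OCc1cc2cc(F)c(F)cc2nc1-c1ccccc1O` likewise gives only a limit in this assay, > 100000 nM. Among the compounds with values here, the one measured step through the methyl position, an at least 2.5-fold higher number from compound 1 to compound 2 (0.39 log units; beyond the scatter), moved compound 2 from a measured number to the limit, so compound 2 stands at the weak end of the set together with compound 3, both at the limit of > 100000 nM in this assay, at which 2 of the 3 values shown sit.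

Compound 4 `OCc1cc2cc(Cl)ccc2nc1-c1ccccc1O` differs from compound 2 by chloro in place of methyl on an aromatic carbon. Within the data shown here, no measured pair swaps chloro for methyl, so no step bears directly on this change; the only related step, an at least 2.5-fold higher number from compound 1 to compound 2 (0.39 log units; beyond the scatter), shows a single substituent at this place cost at least a modest amount, and compound 3 shows a second substituted analogue also at the limit. Compound 4 is therefore expected to stay close to the limit, with a step of a number no higher from compound 2 to compound 4 (the limit leaves the size open) expected to be none beyond the scatter. The estimate for compound 4 is 100000 nM, with a range from 30000 nM to 300000 nM.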

Compound 4, half-maximal inhibitory concentration: 24000 nM
Estimate against measurement, compound 4: 4.2-fold (0.62 log units) above; the measured number lies below the stated range.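

In this assay, this position does not penalise every substituent, as the methyl result alone had suggested: swapping methyl for chloro gives an at least 4.1-fold lower number from compound 2 to compound 4 (0.61 log units; beyond the scatter). Against the unsubstituted parent the same chloro gives a 1.7-fold lower number from compound 1 to compound 4 (0.22 log units; within the scatter), so chloro at this place cannot be told apart from hydrogen, and the weak result belongs to methyl among the three groups compared here. The true size of the methyl-to-chloro step stays open because compound 2 reaches only a limit: the limit of > 100000 nM in this assay, at which 2 of the 4 values shown sit.

As far as these compounds go, only hydrogen, methyl and chloro can be compared at this place, so it remains open whether the methyl result reflects a wider trend among substituents. A methoxy group, an amine or a carboxylic acid at the same carbon would test this, and fluoro alone there would separate that group's contribution from the doubly substituted compound 3.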